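The compounds below may be only part of what the source reports. "The series", "measured", "known", "first", "only" and "open" are said of these compounds alone.

In a functional assay on HepG2 cells (Homo sapiens) for cytotoxicity, read by MTT assay, with a stated time of 24 h (a lower number here means a stronger inhibitor, a higher number a weaker inhibitor), compound 1 `COc1ccc(C2CC(=O)c3cc(OC)c(OC)c(OC)c32)c(OC)c1OC` is recorded only as a limit, >= 250000 nM, not as a number. That limit, (the limit of >= 250000 nM in this assay, at which 1 of the 2 values shown sits), is where one of the two values in this assay sits. Compound 2 `COc1cc(C2CC(=O)c3cc(OC)c(OC)c(OC)c32)cc(OC)c1OC` gives 9000 nM in this assay, and it is the only actual number shown. Compound 3 `COc1cc2c(cc1OC)C(c1cc(OC)c(OC)c(OC)c1)CC2=O` has not yet been measured in this assay. It differs from compound 2 by hydrogen in place of methoxy on an aromatic carbon. Among the compounds with values here, with no measured pair of compounds differing in one place, there is nothing to set the size of the step; the expected step from compound 2 to compound 3, a 1.7-fold higher number from compound 2 to compound 3 (0.22 log units; within the scatter), is a modest loss of potency in this assay, only a little beyond the scatter. Compound 3 is therefore estimated at 15000 nM in this assay, with a range from 5000 nM to 50000 nM.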

Compound 3, half-maximal inhibitory concentration: 112000 nM
Beside the measured number, compound 3's estimate is 7.5-fold (0.87 log units) below it; measured number outside the range, above it.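

In this assay, within the data shown here, the change of methoxy to hydrogen on an aromatic carbon of the ring in the fused system gives the first step that can be read: a 12-fold higher number from compound 2 to compound 3 (1.09 log units; beyond the scatter). This shows that the position is not indifferent to the change, and that this single methoxy group, which compound 3 lacks, goes with much of the potency that compound 2 shows in this cell assay. Nothing measured here accounts for the size of this step.

Only methoxy and hydrogen are shown at this carbon, so it remains open whether a hydroxyl, a fluorine or an amine there would restore the potency of compound 2. Going by these compounds, it also remains open whether the same change on the neighbouring methoxy-bearing carbon of this ring would give a step of similar size.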